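Ester hydrolysis on two cinnamate cores against platelet inhibition

The compounds below may be only part of what the source reports. "The series", "measured", "known", "first", "only" and "open" are said of these compounds alone.

Measured so far:
Compound 1 `CCOC(=O)/C=C/c1cc(OC)c(OCc2nc(C)c(C)nc2C)c(OC)c1` gives 631000 nM in a functional assay on a cell-free system (Platelet, plasma, Oryctolagus cuniculus) for inhibition, with a stated time of 5 min; on this read-out lower numbers stand for stronger inhibition and higher numbers for weaker inhibition.
Compound 2 `CCOC(=O)/C=C/c1ccccc1OCc1nc(C)c(C)nc1C` gives 502000 nM in this assay.
Compound 3 `COc1cc(/C=C/C(=O)O)cc(OC)c1OCc1nc(C)c(C)nc1C` gives 182000 nM in this assay.

Compound 1 and compound 3 share a core, and how that core differs from the core of compound 2 is not broken down here. Compound 1 and compound 2 lie within the scatter of each other. Among the compounds with values here, the one counted change made so far, (hydrogen in place of ethyl on an oxygen next to a carbonyl group), gave a 3.5-fold lower number from compound 1 to compound 3 (0.54 log units; beyond the scatter) in this assay, a modest step.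

Compound 4 `Cc1nc(C)c(COc2ccccc2/C=C/C(=O)O)nc1C` is not yet measured. It differs from compound 2 by hydrogen in place of ethyl on an oxygen next to a carbonyl group, the same change as from compound 1 to compound 3. Because the earlier step was a 3.5-fold lower number from compound 1 to compound 3 (0.54 log units; beyond the scatter), a step of similar size is expected, namely a 3.3-fold lower number from compound 2 to compound 4 (0.52 log units; beyond the scatter). Compound 4 is therefore estimated at 150000 nM, expected between 60000 nM and 400000 nM.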

Compound 4, half-maximal inhibitory concentration: 54000 nM
Compound 4: middle estimate off by 2.8-fold (0.44 log units), on the high side, and the stated range ends above it.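

In this assay the change from ethoxycarbonyl to carboxy gave a 9.3-fold lower number from compound 2 to compound 4 (0.97 log units; beyond the scatter) on this second core, so the direction of the step was the same on both cores shown. The size of the step did not carry over unchanged: the same change on two cores in this assay, a 3.5-fold lower number (0.54 log units; beyond the scatter) from compound 1 to compound 3 and a 9.3-fold lower number (0.97 log units; beyond the scatter) from compound 2 to compound 4, 2.7-fold (0.43 log units) apart, beyond the scatter of two such steps. Two cores are enough to show that the size cannot simply be copied from one core to another, but they do not show which part of the cores goes with the gap, or how a third core would respond.

From the compounds shown here alone, only the ethyl ester and the carboxylic acid appear at this place, so it remains open how a methyl ester or a primary amide would read out here.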